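Swapping an Acid for an Aminotriazole on the Shared Core

This account rests on a few compounds, and the source may have more. Where it says the series, first, only, none or still open, it means among the compounds named here.

Measured compounds:
- Compound 1 `c1ccc(-c2nnn[nH]2)c(-c2ccc(CCc3nc(CC4CCCC4)c[nH]3)cc2)c1`: 16 nM in a functional assay for agonist activity at Bombesin receptor subtype-3 (Mus musculus); a higher number here means that more compound is needed for the effect, a lower number that less compound is needed
- Compound 2 `O=C1NC(=O)C(c2ccccc2-c2ccc(CCC3N=CC(CC4CCCC4)=N3)cc2)S1`: "not determined" (no result reported) in this assay
- Compound 3 `CCC(C)(C)Cc1c[nH]c(CCc2ccc(-c3ccccc3OCC(=O)O)cc2)n1`: "not determined" (no result reported) in this assay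

Compound 1 is the only one of the three with a number in this assay, where compound 1 gives 16 nM. Compound 2 and compound 3 share a related scaffold but carry no reported result, so compound 3 stands without a single number, alongside one further entry in the same situation.

The unmeasured compound 4 `CCC(C)(C)Cc1c[nH]c(CCc2ccc(-c3ccccc3OCc3nc(N)n[nH]3)cc2)n1` is derived from compound 3 by one change: 3-amino-1H-1,2,4-triazol-5-yl in place of carboxy on a saturated chain carbon bound to an oxygen on an aromatic ring. For the measured compounds named here, since compound 3 has no value, no step can be measured between them, and no comparable pair of measured compounds is available to gauge the size of such a swap. The expectation therefore rests on compound 1 alone, whose 16 nM shows that this scaffold can reach strong agonism in this assay. Compound 4 is expected to be weaker than that, with an estimated value of 200 nM, in a range from 30 nM to 2000 nM.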

Compound 4, half-maximal effective concentration: 4.6 nM
Estimate against measurement, compound 4: 43-fold (1.64 log units) above; measured number below the stated range.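

Compound 3 has no single number to set against compound 4, so no step can be read between them. The compounds shown leave open what replacing carboxy with 3-amino-1H-1,2,4-triazol-5-yl does on its own. Nothing shown here explains the value of compound 4.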